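Thiophene to Pyridine Swap Tried on a Weaker Core

The compounds below may be only part of what the source reports. "The series", "measured", "known", "first", "only" and "open" are said of these compounds alone.

Measured in a functional assay on BMDM cells (Mus musculus, strain C57BL/6) for inhibition, with a stated time of 2 days; on this read-out higher numbers stand for weaker inhibition and lower numbers for stronger inhibition:
compound 1 `Cc1csc(NC(=O)Cn2cc(-c3ccncc3)nn2)n1` gives 100 nM
compound 2 `O=C(Cn1cc(-c2cccs2)nn1)Nc1nc2ccccc2s1` gives 21400 nM
compound 3 `Cc1csc(NC(=O)Cn2cc(-c3cccs3)nn2)n1` gives 40 nM

Compound 3 and compound 1 share one core and differ only by pyridin-4-yl in place of thiophen-2-yl on an aromatic carbon, a change that brought a 2.5-fold higher number from compound 3 to compound 1 (0.40 log units; beyond the scatter). Compound 2 carries a different core; the difference between the two cores is not broken down here, and compound 2 stands far above compound 1 and compound 3 in this assay.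

Compound 4 `O=C(Cn1cc(-c2ccncc2)nn1)Nc1nc2ccccc2s1` has not been measured. It differs from compound 2 by pyridin-4-yl in place of thiophen-2-yl on an aromatic carbon, the same change as from compound 3 to compound 1, at the same place. Compound 4 is therefore expected to show a 2.3-fold higher number from compound 2 to compound 4 (0.37 log units; beyond the scatter), resting on the earlier 2.5-fold higher number from compound 3 to compound 1 (0.40 log units; beyond the scatter). The estimate for compound 4 is 50000 nM, expected between 15000 nM and 150000 nM.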

Compound 4, half-maximal inhibitory concentration: 50 nM
Estimate against measurement, compound 4: 1000-fold (3.00 log units) above; the measured number lies below the stated range.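

In this assay, putting pyridin-4-yl in place of thiophen-2-yl on the second core gave a 430-fold lower number from compound 2 to compound 4 (2.63 log units; beyond the scatter). The same change therefore did not carry over from one core to the other: the same change on two cores in this assay, a 2.5-fold higher number (0.40 log units; beyond the scatter) from compound 3 to compound 1 and a 430-fold lower number (2.63 log units; beyond the scatter) from compound 2 to compound 4, 1100-fold (3.03 log units) apart, beyond the scatter of two such steps. In this series, a step measured on one core cannot be relied on to predict the step on another, but these two pairs do not show which feature of the cores sets the steps apart, or how the change would behave on a third core.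

The compounds shown leave open how other groups at this place, such as a phenyl ring, an amine or a carboxylic acid, would behave on either core.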